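Aryl exchange on the carbonyl carbon of the shared core

A few compounds are considered here, and "the series" means these few. Any claim that something is new, unique, unknown or untested is made for them only; others in the source may bear on it.

Compound 2 `COc1cc2ncnc(NNC(=S)NC(=O)c3cccc(Cl)c3)c2cc1OC` stands lowest of the two numbers measured in a functional assay on CNE-2 cells (Homo sapiens) for cytotoxicity, read by MTT assay, with a stated time of 72 h (a higher number here means a weaker inhibitor, a lower number a stronger inhibitor), at 7460 nM. Compound 1 `COc1cc2ncnc(NNC(=S)NC(=O)c3ccc(F)cc3)c2cc1OC` gives 16100 nM. Among the compounds with values here, the single measured step is a 2.2-fold lower number from compound 1 to compound 2 (0.33 log units; beyond the scatter). Compound 3 `COc1cc2ncnc(NNC(=S)NC(=O)c3ccccc3OC)c2cc1OC` differs from compound 2 by 2-methoxyphenyl in place of 3-chlorophenyl on a carbonyl carbon. Within the data shown here, only the step of a 2.2-fold lower number from compound 1 to compound 2 (0.33 log units; beyond the scatter) bears on this change, and it concerns a different exchange of the ring on the carbonyl carbon; no second example of such an exchange is measured, so a step of at most similar size, in either direction, is expected. Compound 3 is expected at 10000 nM, within a range of 4000 nM to 25000 nM. This amounts to an expected step of a 1.3-fold higher number from compound 2 to compound 3 (0.13 log units; within the scatter).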

Compound 3, half-maximal inhibitory concentration: 8410 nM
Beside the measured number, compound 3's estimate is 1.2-fold (0.08 log units) above it; the range from low to high includes it.
By their numbers in this assay, from the lowest: compounds 2, 3 and 1 (each within the scatter of the next, the first and the last beyond it).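

In this assay, 2-methoxyphenyl on the carbonyl carbon brings an oxygen and a hydrogen-bond acceptor into the group, yet the step of a 1.1-fold higher number from compound 2 to compound 3 (0.05 log units; within the scatter) stays within the scatter of 3-chlorophenyl. The step of a 1.9-fold lower number from compound 1 to compound 3 (0.28 log units; within the scatter) is also within the scatter, so compound 3 cannot be separated from either earlier compound, although those two are separated from each other. No data on hand give a reason for these numbers. Still open, from the compounds shown here alone, is whether a ring carrying an amine or a carboxylic acid, or a saturated alkyl chain in place of the ring, leaves the number in this range.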